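Swapping the bromo-bearing ring for a methoxy-bearing ring

A few compounds are considered here, and "the series" means these few. Any claim that something is new, unique, unknown or untested is made for them only; others in the source may bear on it.

Measured compounds and their values in a functional assay on B16-F10 cells (Mus musculus) for antiproliferative activity, read by MTT assay, with a stated time of 48 h; on this read-out lower numbers stand for stronger inhibition and higher numbers for weaker inhibition:
compound 1 `CCCCOc1ccc(C(=O)/C=C/c2c(/C=C/c3ccc(OC)cc3)cc(OC)cc2OC)cc1` gives 5.3 ug/mL
compound 2 `COc1ccc(/C=C/c2cc(OC)cc(OC)c2/C=C/C(=O)c2ccc(C)c(C)c2)cc1` gives 1.4 ug/mL
compound 3 `COc1ccc(/C=C/c2cc(OC)cc(OC)c2/C=C/C(=O)c2ccc(Br)cc2)cc1` gives 6.5 ug/mL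

Compound 3 shows the highest number of the three. Its gap to compound 1 is within the scatter, while the step of a 4.6-fold higher number from compound 2 to compound 3 (0.67 log units; beyond the scatter) is beyond it.

Compound 4 `COc1ccc(/C=C/c2cc(OC)cc(OC)c2/C=C/C(=O)c2cccc(OC)c2)cc1` differs from compound 3 by 3-methoxyphenyl in place of 4-bromophenyl on a carbonyl carbon. Among the compounds with values here, no measured pair tests this exact change. The step of a 1.2-fold higher number from compound 1 to compound 3 (0.09 log units; within the scatter), where a butoxy group on that ring gave way to bromo, stayed within the scatter, so an oxygen-bearing group in place of bromo on this ring has so far made little difference. The step of a 3.8-fold lower number from compound 1 to compound 2 (0.58 log units; beyond the scatter) shows that ring changes here can matter, yet nothing points in a clear direction for compound 4.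

Compound 4 is therefore expected to sit near compound 3, with an estimated step of a 1.3-fold lower number from compound 3 to compound 4 (0.11 log units; within the scatter) and a value around 5 ug/mL, between 2 ug/mL and 12 ug/mL.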

Compound 4, half-maximal inhibitory concentration: 4.3 ug/mL
Compound 4: the middle estimate sits 1.2-fold (0.07 log units) above what was measured; the measured number falls inside the stated range.
By their numbers in this assay, from the lowest: compound 2; then compounds 4, 1 and 3 (each within the scatter of the next).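

In this assay, 3-methoxyphenyl on the carbonyl carbon sits level with both 4-bromophenyl (a 1.5-fold lower number from compound 3 to compound 4 (0.18 log units; within the scatter)) and 4-butoxyphenyl (a 1.2-fold lower number from compound 1 to compound 4 (0.09 log units; within the scatter)). Only 3,4-dimethylphenyl stands apart (a 3.1-fold higher number from compound 2 to compound 4 (0.49 log units; beyond the scatter)), so among these four compounds, three different rings now group together and compound 2 alone breaks away. Nothing measured here explains that gap. Still open, on these data alone, is whether a single methyl group on this ring would match the two in compound 2, and whether an amine or a carboxylic acid there would shift the number.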